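Chloro in Place of Methoxy: Expecting the Next Step

The source may report more compounds than this note shows. Statements on the series, on what has been measured and on what is new or still open speak of the compounds shown alone.

compound 1 `COc1ccc2c(c1)c(CCCC(=O)N1CCOCC1)c(C)n2Cc1ccccc1` gives 54.2%
compound 2 `Cc1c(CCCC(=O)N2CCOCC2)c2cc(Cl)ccc2n1Cc1ccc(Cl)cc1` gives 37.9%
compound 3 `COc1ccc2[nH]c(C)c(CCCC(=O)N3CCOCC3)c2c1` gives 72.9%

All three were measured in an assay on cells for inhibition of Polyunsaturated fatty acid 5-lipoxygenase (Rattus norvegicus), tested at 5 uM; a higher number here means more inhibition at the concentration tested (going by the name of the read-out), a lower number less inhibition. Compound 3 stands highest of the three; compound 1 is its nearest neighbour and compound 2 the furthest, and both gaps lie beyond the scatter. Among the measured compounds shown here, the only step between two compounds that differ in one place is a number 18.7 percentage points higher from compound 1 to compound 3 (beyond the scatter), a modest rise on removing the benzyl group from the ring nitrogen.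

Compound 4 `Cc1[nH]c2ccc(Cl)cc2c1CCCC(=O)N1CCOCC1` is not yet measured. It differs from compound 3 by chloro in place of methoxy on an aromatic carbon. For the measured compounds named here, no measured step matches this change. Compound 1 and compound 2 differ at the same position, but they also differ in the group on the ring nitrogen, so their two values cannot be read as a clean guide to the methoxy-to-chloro swap alone. Compound 1 gives 54.2%. Compound 2 gives 37.9%. Those two values do at least point toward the chloro compound being the lower of the pair.

On that weak footing, compound 4 is expected to come out somewhat below compound 3, by a step of a number 12.9 percentage points lower from compound 3 to compound 4 (beyond the scatter), though a result within the scatter would not be surprising. The estimate for compound 4 in this assay is 60%, with a range from 40% to 80%.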

Compound 4, a percentage reported as inhibition, at one concentration (the size of the read-out at that concentration, not a potency): 71.3%
Compound 4: the middle estimate sits 11.3 percentage points below what was measured; measured number inside the range.
By their numbers in this assay, from the lowest: compound 2; then compound 1; then compounds 4 and 3 (each within the scatter of the next).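

In this assay, putting chloro in place of methoxy on this aromatic carbon gives a number 1.6 percentage points lower from compound 3 to compound 4 (within the scatter), so the two groups read alike here when the ring nitrogen carries hydrogen. The earlier compounds shown here could not show this, as compound 1 and compound 2 differ in two places, and the methoxy group, with two heavy atoms and a hydrogen-bond acceptor, can now be compared directly with the single chlorine atom, which has no acceptor. The ring nitrogen also gains a second clean comparison, with a number 33.4 percentage points higher from compound 2 to compound 4 (beyond the scatter), which points the same way as a number 18.7 percentage points higher from compound 1 to compound 3 (beyond the scatter): in both pairs, the compound with hydrogen on that nitrogen has the higher number, whether the aromatic carbon carries chloro or methoxy.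

Still open, on these data alone, is whether other groups on this aromatic carbon, such as fluoro, hydroxyl or an amine, would read alike too, and whether a longer chain leading to the amide carbonyl would alter the picture. Nothing available here explains why methoxy and chloro read alike or why hydrogen on the nitrogen goes with the higher numbers.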